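Aryl groups on the ring nitrogen of a thiazolidinone amide

A few compounds are considered here, and "the series" means these few. Any claim that something is new, unique, unknown or untested is made for them only; others in the source may bear on it.

Compound 1 `CCN1C(=O)CSC1c1cccc(C(=O)NCCCCc2ccccc2)c1`: in a functional assay on U2OS cells (Homo sapiens) for inhibition, read by CCK-8 assay, with a stated time of 72 h, tested at 1 uM (on this read-out lower numbers stand for less inhibition and higher numbers for more inhibition at the one concentration tested (going by the name of the read-out)), compound 1 gives 13%
Compound 2 `COc1cc(F)ccc1N1C(=O)CSC1c1cccc(C(=O)NCCCCc2ccccc2)c1`: in this assay compound 2 gives 34%
Compound 3 `O=C(NCCCCc1ccccc1)c1cccc(C2SCC(=O)N2c2cccc(F)c2)c1`: in this assay compound 3 gives 39%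

Compound 3 stands highest of the three numbers. Its nearest neighbour is compound 2, with a number 5 percentage points higher from compound 2 to compound 3 (within the scatter), so the two cannot be set in order. The furthest is compound 1, with a number 26 percentage points higher from compound 1 to compound 3 (beyond the scatter), and the related change shows a number 21 percentage points higher from compound 1 to compound 2 (beyond the scatter); both steps replace the ethyl group on the amide-type nitrogen in the ring by an aryl group and both lie beyond the scatter.

Compound 4 `COc1ccc(N2C(=O)CSC2c2cccc(C(=O)NCCCCc3ccccc3)c2)c(OC)c1` differs from compound 3 by 2,4-dimethoxyphenyl in place of 3-fluorophenyl on an amide-type nitrogen in a ring. The change keeps an aryl group at this position and only alters its substituents. For the measured compounds named here, the steps that bear on it are the one from compound 1 to compound 3 and the one from compound 1 to compound 2, which show that the aryl group itself carries the gain, while the step from compound 2 to compound 3 shows that changing the substituents on that aryl group gave no difference beyond the scatter. The step from compound 3 to compound 4 in this assay is therefore expected to be a number 4 percentage points lower from compound 3 to compound 4 (within the scatter), not beyond the scatter. Compound 4 is estimated to give 35% in this assay, with a range from 20% to 50%.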

Compound 4, a percentage reported as inhibition, at one concentration (the size of the read-out at that concentration, not a potency): 37%
Beside the measured number, compound 4's estimate is 2 percentage points below it; low and high end bracket the measured number.
By their numbers in this assay, from the lowest: compound 1; then compounds 2, 4 and 3 (each within the scatter of the next).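

Compound 4 adds a third aryl group at the amide-type nitrogen in a ring, and in this assay the substituents on that aryl group again make no readable difference: 2,4-dimethoxyphenyl in place of 3-fluorophenyl gives (a number 2 percentage points lower from compound 3 to compound 4 (within the scatter)), and methoxy in place of fluoro on an aromatic carbon gives (a number 3 percentage points higher from compound 2 to compound 4 (within the scatter)). This holds although the entering group has more heavy atoms and two hydrogen-bond acceptors where 3-fluorophenyl has none, while the step from ethyl (a number 24 percentage points higher from compound 1 to compound 4 (beyond the scatter)) lies beyond the scatter like the two before it. Nothing here accounts for these results.

The compounds shown leave open whether a benzyl or cyclohexyl group at this position would match the aryl groups. They also leave open how a pyridine ring, or an amine or carboxylic acid on the aryl ring, would read in this assay.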